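The source may hold more compounds than are shown below. What is called first, only, known or untested is meant among the compounds shown, and "the series" means these compounds.

Measured in a functional assay on A2780 cells (Homo sapiens) for antiproliferative activity, read by MTT assay, with a stated time of 48 h (a higher number here means a weaker inhibitor of growth, a lower number a stronger inhibitor of growth), so far:
Compound 1 `CCOC(=O)N1N=C(c2cccc(OC)c2)CC1c1cc(OC)c(OC)c(OC)c1` gives 7300 nM as a number
Compound 2 `COC(=O)N1N=C(c2ccccc2)CC1c1ccccc1` gives > 10000 nM as a limit of the assay

For compound 2 only a limit is known, and the limit of > 10000 nM in this assay, at which 1 of the 2 values shown sits, is all that can be said of where it stands. Compound 3 `COC(=O)N1N=C(c2ccccc2)CC1c1ccc(OC)cc1` departs from compound 2 in one place, with methoxy in place of hydrogen on an aromatic carbon as the whole change, methoxy in place of hydrogen on an aromatic carbon. Compound 1 also carries methoxy groups and gives 7300 nM in this assay but differs from compound 2 in several places. Only a small step toward stronger growth inhibition is therefore expected in this assay and none beyond the scatter is equally possible. The expected change is a step that the limit leaves unreadable from compound 2 to compound 3 by this estimate. Compound 3 is estimated at 11000 nM with an expected range of 4000 nM to 30000 nM for its value.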

Compound 3, concentration for 50% growth inhibition: > 10000 nM
Compound 3: no number, only a limit; the forecaster's own chance of this, stated with the estimate: 60%; the middle value lies beyond the limit too.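

In this assay no step can be read from compound 2 to compound 3, since each gives only a limit of the assay: the limit of > 10000 nM in this assay, at which 2 of the 3 values shown sit. As far as these compounds go, whether methoxy in place of hydrogen on an aromatic carbon changes growth inhibition at all stays open.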